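Working notes: aryl substitution on a ring amide nitrogen

This account rests on a few compounds, and the source may have more. Where it says the series, first, only, none or still open, it means among the compounds named here.

Compound 1 `O=C1NNC(=O)C2(CSC3=C2C(=O)c2ncccc2C3=O)N1` is the reference point of this pair. In a functional assay on CCRF-SB cells (Homo sapiens) for antiproliferative activity, read by MTT assay, with a stated time of 96 h (a lower number here means a stronger inhibitor, a higher number a weaker inhibitor), compound 1 gives 48 nM, the higher of the two numbers recorded so far. Compound 2 `Cc1ccc(N2C(=O)NC3(CSC4=C3C(=O)c3ncccc3C4=O)C2=O)cc1` gives 20 nM in this assay, a lower number than compound 1, with a gap that lies beyond the scatter. Among the compounds with values here, no step between measured compounds that differ in a single place is available, so the series offers no direct single-point guidance. Compound 3 `O=C1NN(c2ccc(Cl)cc2)C(=O)C2(CSC3=C2C(=O)c2ncccc2C3=O)N1` is not yet measured. It differs from compound 1 by 4-chlorophenyl in place of hydrogen on an amide-type nitrogen in a ring. A modest decrease in number is expected for compound 3, because compound 2 gives 20 nM where compound 1 gives 48 nM, though that pair is not a single-point comparison. Compound 3 is estimated at 25 nM, within 10 nM to 65 nM. The expected step of a 1.9-fold lower number from compound 1 to compound 3 (0.28 log units; within the scatter) is small, near the edge of the scatter.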

Compound 3, half-maximal inhibitory concentration: 51 nM
For compound 3 the middle estimate is 2.0-fold (0.31 log units) below the measured one; low and high end bracket the measured number.
By their numbers in this assay, from the lowest: compound 2; then compounds 1 and 3 (each within the scatter of the next).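

In this assay, 4-chlorophenyl in place of hydrogen on the amide-type nitrogen in a ring gives a 1.1-fold higher number from compound 1 to compound 3 (0.03 log units; within the scatter), so the two compounds cannot be told apart. The hydrogen on this nitrogen is therefore not needed to keep the number, and this position accepts a six-membered aromatic ring of carbon only, at least for this one group in this one read-out. Nothing on hand bears on why the added group leaves the number in place.

On these data alone, whether the same nitrogen would behave alike with a small group such as methyl, or with a longer chain ending in an amine, stays open. Also open, as far as these compounds go, is whether the chlorine matters at all, which an unsubstituted phenyl or a phenyl bearing a carboxylic acid would test.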